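The source may report more compounds than this note shows. Statements on the series, on what has been measured and on what is new or still open speak of the compounds shown alone.

Measured so far:
compound 1 `CC(C)CNc1nnc(SCC(=O)N(Cc2cccc([N+](=O)[O-])c2)c2ccc(F)cc2)s1` — 36%
compound 2 `C=CCNc1nnc(SCC(=O)N(Cc2cccc([N+](=O)[O-])c2)c2ccc(F)cc2)s1` — 38.1%

In an assay on isolated protein for inhibition of Amine oxidase [flavin-containing] B (Homo sapiens), read by fluorescence and Amplex Red, with a stated time of 30 min, tested at 1 mM (on this read-out higher numbers stand for a stronger effect at the one concentration tested and lower numbers for a weaker effect), compound 2 holds the top number of the two, yet the step of a number 2.1 percentage points higher from compound 1 to compound 2 (within the scatter) is within the scatter, so it is not set apart from compound 1. Compound 3 `CCNc1nnc(SCC(=O)N(Cc2cccc([N+](=O)[O-])c2)c2ccc(F)cc2)s1` differs from compound 2 by methyl in place of vinyl on a saturated chain carbon bound to a nitrogen on an aromatic ring. Among the measured compounds shown here, the one step bearing on it, a number 2.1 percentage points higher from compound 1 to compound 2 (within the scatter), altered the same place with a different chain and stayed within the scatter. Compound 3 is therefore expected to show no step beyond the scatter, a number 1.1 percentage points lower from compound 2 to compound 3 (within the scatter). Compound 3 is estimated at 37%, between 25% and 49%.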

Compound 3, a percentage reported as inhibition, at one concentration (the size of the read-out at that concentration, not a potency): 41.3%
For compound 3 the middle estimate is 4.3 percentage points below the measured one; measured number inside the range.
By their numbers in this assay, from the lowest: compounds 1, 2 and 3 (each within the scatter of the next).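

In this assay, methyl in place of vinyl gives a number 3.2 percentage points higher from compound 2 to compound 3 (within the scatter), and methyl in place of isopropyl gives a number 5.3 percentage points higher from compound 1 to compound 3 (within the scatter). On a saturated chain carbon bound to a nitrogen on an aromatic ring, methyl, vinyl and isopropyl therefore remain unseparated, and the change from the larger groups to methyl gives no step beyond the scatter. No measured data bear on why these groups read alike. Open, from the compounds shown here alone, is whether a longer chain, a phenyl ring, an amine or a carboxylic acid at this place would move the number beyond the scatter.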